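The compounds below may be only part of what the source reports. "The series", "measured", "known", "first", "only" and "open" are said of these compounds alone.

Measured compounds so far:
compound 1 `C/N=C(/NC#N)NCCCn1nc(-c2ccccc2)ccc1=O`: in a functional assay on the whole organism with Rattus norvegicus as the target (a lower number here means that less compound is needed, a higher number that more compound is needed for the effect), compound 1 gives 78.1 mg/kg.
compound 3 `C/N=C(/NC#N)NCCCCCn1nc(-c2ccccc2)ccc1=O`: in this assay compound 3 gives 76.2 mg/kg.
compound 2 `C/N=C(/NC#N)NCCCCCCn1nc(-c2ccccc2)ccc1=O`: in this assay compound 2 reaches only a limit, > 100 mg/kg.

Compound 1 stands at the higher of the two numbers, with compound 3 within the scatter of it. The limit for compound 2 is the limit of > 100 mg/kg in this assay, at which 1 of the 3 values shown sits. Among the measured compounds shown here, the single measured step, an at least 1.3-fold lower number from compound 2 to compound 3 (0.11 log units; that floor lies within the scatter), concerns the chain only and leaves the group changed here untouched.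

Compound 4 `CC/N=C(\S)NCCCn1nc(-c2ccccc2)ccc1=O` differs from compound 1 by a group of 5 heavy atoms (3 carbon, 1 nitrogen, 1 sulfur; no ring) in place of a group of 6 heavy atoms (3 carbon, 3 nitrogen; no ring), on an amine nitrogen. For the measured compounds named here, no measured step bears on this exchange, so no direction can be read from the series. Compound 4 is therefore expected near compound 1, with a wide range: 75 mg/kg, between 30 mg/kg and 100 mg/kg. The expected step is a 1.0-fold lower number from compound 1 to compound 4 (0.02 log units; within the scatter).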

Compound 4, dose for half-maximal effect: 88.2 mg/kg
Beside the measured number, compound 4's estimate is 1.2-fold (0.07 log units) below it; the range from low to high includes it.
By their numbers in this assay, from the lowest: compounds 3, 1 and 4 (each within the scatter of the next). At a limit, above all of these: compound 2.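

At the amine nitrogen, putting the sulfur-bearing group of 5 heavy atoms in place of the group of 6 heavy atoms, which removes the triple bond, gives a 1.1-fold higher number from compound 1 to compound 4 (0.05 log units; within the scatter) in this assay. Among the compounds shown here, this is the first reading at this position, and the exchange stays within the scatter. Nothing measured on these compounds accounts for the step. Open, going by these compounds, is whether an acetyl group or a carboxylic acid on this amine nitrogen would give a step beyond the scatter. Also open, on these data alone, is whether the sulfur-bearing group gives the same reading on a longer chain.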